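Swapping a hydroxyethyl for a phenyl on a sulfonamide

The source may hold more compounds than are shown below. What is called first, only, known or untested is meant among the compounds shown, and "the series" means these compounds.

Of the compounds shown here, two have been measured in a functional assay on HeLa cells (Homo sapiens) for antiproliferative activity, read by CCK-8 assay, with a stated time of 72 h; on this read-out lower numbers stand for stronger inhibition of growth and higher numbers for weaker inhibition of growth. Compound 1, `CC[C@@H]1C(=O)N(C)c2cnc(Nc3ccc(S(=O)(=O)NCCO)cc3)nc2N1C1CCCC1`, gives 459 nM in this assay, the lower of the two numbers. Compound 2, `CC[C@@H]1C(=O)N(C)c2cnc(-n3ccc4ccccc43)nc2N1C1CCCC1`, gives 33900 nM in this assay, a far higher number that lies well beyond the usual scatter, so compound 1 is clearly the stronger growth inhibitor of the pair.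

Compound 3, `CC[C@@H]1C(=O)N(C)c2cnc(Nc3ccc(S(=O)(=O)Nc4ccccc4)cc3)nc2N1C1CCCC1`, has not yet been measured. It is built from compound 1 by a single change: phenyl in place of 2-hydroxyethyl on a sulfonamide nitrogen. For the measured compounds named here, no measured pair in this set shows the effect of exactly this change, so nothing here sets its size or direction. A modest step, possibly a small rise in the number, is expected from compound 1 to compound 3, as a 1.4-fold higher number from compound 1 to compound 3 (0.15 log units; within the scatter) in this assay. On that basis compound 3 is estimated to give 650 nM in this assay, most likely between 150 nM and 2800 nM.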

Compound 3, concentration for 50% growth inhibition: 5140 nM
Estimate against measurement, compound 3: 7.9-fold (0.90 log units) below, outside the stated range (above it).
By their numbers in this assay, from the lowest: compound 1; then compound 3; then compound 2.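

In this assay, the sulfonamide nitrogen proves sensitive to what it carries: phenyl in place of 2-hydroxyethyl gives an 11-fold higher number from compound 1 to compound 3 (1.05 log units; beyond the scatter) and so a large loss of growth inhibition. Compound 1 and compound 3 differ in this one place only, so the loss goes with this single swap, which removes an open chain with a hydrogen-bond donor and acceptor and brings in an aromatic ring with neither. Nothing available gives a reason for the loss.

The compounds shown cannot tell whether the ring itself or the absence of the hydroxyl group matters more, as the two changes arrive together. A plain ethyl group, a 2-aminoethyl chain or a longer 3-hydroxypropyl chain on the same nitrogen would be needed to pull these apart.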